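This account rests on a few compounds, and the source may have more. Where it says the series, first, only, none or still open, it means among the compounds named here.

Compounds measured so far in an assay on HEK293 cells for inhibition of neurogenic locus notch homolog protein 1 (Homo sapiens), read by a luciferase reporter and resazurin assay, with a stated time of 16 h; on this read-out lower numbers stand for stronger inhibition and higher numbers for weaker inhibition:

Compound 1 `CC1=C(C(=O)OCc2cnccn2)C(c2cccc(Br)c2)C2=C(CC(C)(C)CC2=O)N1` gives 860 nM.
Compound 2 `CC1=C(C(=O)OCc2ccc(C(C)(C)C)cc2)C(c2cccc(Br)c2)C2=C(CC(C)(C)CC2=O)N1` gives 4270 nM.

For the measured compounds named here, compound 2 stands at the highest of the two numbers in this assay, and the only neighbour, compound 1, sits at a lower number: a 5.0-fold higher number from compound 1 to compound 2 (0.70 log units; beyond the scatter). Going by the values given here, that step, the only one bearing on the change considered here, came from swapping the pyrazin-2-yl group for the 4-(tert-butyl)phenyl group on the saturated chain carbon bound to the oxygen next to the carbonyl group, so it shows that this position is sensitive to what is attached there.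

Compound 3 `CC1=C(C(=O)O[C@H](CC#N)c2ccccc2)C(c2cccc(Br)c2)C2=C(CC(C)(C)CC2=O)N1` is not yet measured. It differs from compound 2 at the same position: a group of 10 heavy atoms (9 carbon, 1 nitrogen; one six-membered aromatic ring of carbon only) in place of a group of 11 heavy atoms (11 carbon; one six-membered aromatic ring of carbon only), on an oxygen next to a carbonyl group. The group that enters keeps one six-membered aromatic ring of carbon only but brings a triple bond outside aromatic rings, one hydrogen-bond acceptor and a defined stereocentre, while the tert-butyl part leaves. Since the step from compound 1 to compound 2 was modest and moved the number up, and the new group again alters this very position, a modest step in this assay is expected, most likely toward a lower number, of about a 2.8-fold lower number from compound 2 to compound 3 (0.45 log units; beyond the scatter). Compound 3 is therefore estimated at 1500 nM, with a range from 400 nM to 6000 nM.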

Compound 3, half-maximal inhibitory concentration: > 10000 nM
Compound 3: no number, only a limit; the forecaster's own chance of this, stated with the estimate: 5%; at least 6.6-fold (0.82 log units) between middle value and limit.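

In this assay compound 3 gives > 10000 nM, which is a limit of the assay and not a number, and it is the only compound shown that gives one: the limit of > 10000 nM in this assay, at which 1 of the 3 values shown sits.

Even so, the steps can be read in one direction: the change on the oxygen next to a carbonyl group gives an at least 2.3-fold higher number from compound 2 to compound 3 (0.36 log units; beyond the scatter), and the comparison with the pyrazin-2-yl group gives an at least 11-fold higher number from compound 1 to compound 3 (1.06 log units; beyond the scatter). The earlier pair showed only a modest step at this position, whereas these results show that a large step is possible here and that keeping a six-membered aromatic ring of carbon only does not by itself hold the number in place.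

The entering group differs from 4-(tert-butyl)benzyl in its nitrile, its defined stereocentre and the loss of the tert-butyl part, and the compounds shown cannot separate these changes or give the full size of either step. A plain benzyl group, the opposite stereocentre, or an amine or a carboxylic acid in place of the nitrile would each test one part of this change.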